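The source may report more compounds than this note shows. Statements on the series, on what has been measured and on what is new or still open speak of the compounds shown alone.

Measured so far:
compound 1 `CCc1ccc(-c2nc3c(c(C)nn3-c3ccccc3)c(-c3ccccc3[N+](=O)[O-])c2C#N)cc1` — > 20000 nM
compound 2 `Cc1ccc(-c2nc3c(c(C)nn3-c3ccccc3)c(-c3ccccc3O)c2C#N)cc1` — 22200 nM

In an ADME assay on BJ cells (Homo sapiens) for cytotoxicity, with a stated time of 72 h (on this read-out lower numbers stand for an effect already at smaller amounts and higher numbers for an effect only at larger amounts of compound), compound 1 reports only a limit, > 20000 nM, not a number; (the limit of > 20000 nM in this assay, at which 1 of the 2 values shown sits). Among the measured compounds shown here, compound 2 gives 22200 nM in this assay, the single number so far. Compound 3 `CCc1cccc(-c2nc3c(c(C)nn3-c3ccccc3)c(-c3ccccc3O)c2C#N)c1` is not yet measured; it differs from compound 2 by 3-ethylphenyl in place of 4-methylphenyl on an aromatic carbon. For the measured compounds named here, no step between measured compounds that differ in one place exists, so its size cannot be read from the series. The step in this assay is expected to be a 1.0-fold lower number from compound 2 to compound 3 (0.00 log units; within the scatter), none beyond the usual scatter. Compound 3 is estimated at 22000 nM, between 10000 nM and 45000 nM.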

Compound 3, half-maximal effective concentration: > 20000 nM
Compound 3 was reported as a limit; the forecaster's own chance of this, stated with the estimate: 40%; the middle value does not contradict the limit.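

No step can be read from compound 2 to compound 3, since compound 3 gives a limit and not a number: the limit of > 20000 nM in this assay, at which 2 of the 3 values shown sit.

On these data alone, whether 3-ethylphenyl in place of 4-methylphenyl changes the read-out in this assay at all stays open.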